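Iodo to bromo on a shared core

This account rests on a few compounds, and the source may have more. Where it says the series, first, only, none or still open, it means among the compounds named here.

In a functional assay on MIA PaCa-2 cells (Homo sapiens) for inhibition (on this read-out higher numbers stand for weaker inhibition and lower numbers for stronger inhibition), compound 1 (`O=C1O/C(=C\Cn2cc(I)c(=O)[nH]c2=O)C(OCc2ccccc2)=C1OCc1ccccc1`) gives 80000 nM as its result. The chloro analogue, compound 2 (`O=C1O/C(=C\Cn2cc(Cl)c(=O)[nH]c2=O)C(OCc2ccccc2)=C1OCc1ccccc1`), gives 40000 nM in the same test. Going by the values given here, these are the only two numbers available, and they lie within the scatter of each other, so compound 1 stands level with its one neighbour.

Compound 3 (`O=C1O/C(=C\Cn2cc(Br)c(=O)[nH]c2=O)C(OCc2ccccc2)=C1OCc1ccccc1`) has not yet been measured. Its change from compound 1 is bromo in place of iodo on an aromatic carbon and amounts to bromo in place of iodo on an aromatic carbon. Among the compounds with values here, one measured step bears on this, the exchange of chloro for iodo at the same place, which is a 2.0-fold lower number from compound 1 to compound 2 (0.30 log units; within the scatter) and stays within the scatter. Within the data shown here, with only that step as a guide, no shift beyond the scatter is expected. The estimated step is a 1.6-fold lower number from compound 1 to compound 3 (0.20 log units; within the scatter) and remains within the scatter. Compound 3 is expected at 50000 nM with 25000 nM to 100000 nM as the estimated range.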

Compound 3, half-maximal inhibitory concentration: 80000 nM
The estimate for compound 3 lay 1.6-fold (0.20 log units) below the measured number, within the range that was stated.
By their numbers in this assay, from the lowest: compounds 2, 1 and 3 (each within the scatter of the next).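

In this assay, bromo on this aromatic carbon of the six-membered aromatic ring with 2 nitrogen gives no change at the digits printed from compound 1 to compound 3 (within the scatter), while the exchange of chloro for bromo gives a 2.0-fold higher number from compound 2 to compound 3 (0.30 log units; within the scatter). With a third halogen now at this place, every step among the iodo, chloro and bromo compounds lies within the scatter, so this assay does not separate these three substituents. Nothing available explains this lack of separation.

The compounds shown leave open whether a group other than these three halogens, such as an amine or a carboxylic acid, would move the number beyond the scatter at this place. They also leave open whether any change elsewhere on the shared core, such as a hydroxyl in place of a benzyloxy group, would do so.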